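Adding a methoxy group to the benzyl arm

This account rests on a few compounds, and the source may have more. Where it says the series, first, only, none or still open, it means among the compounds named here.

Compound 1 `CCOC(=O)Nc1cc2c(nc(S)n2N)c(N)n1` is the smallest member of this set, with a free sulfur-bound hydrogen. In a functional assay on L1210 cells (Mus musculus) for inhibition (on this read-out higher numbers stand for weaker inhibition and lower numbers for stronger inhibition), compound 1 gives > 30000 nM, which is a limit of the assay rather than a number. Compound 2 `CCOC(=O)Nc1cc2c(nc(SCc3ccccc3)n2N)c(N)n1` carries a benzyl group on that sulfur, and in this assay compound 2 gives 600 nM. For the measured compounds named here, the single measured step is an at least 50-fold lower number from compound 1 to compound 2 (1.69 log units; beyond the scatter); it starts from the limit of > 30000 nM in this assay, at which 1 of the 2 values shown sits, so only a lower bound on its size is known. Among the values shown, compound 2 holds the only actual number, the other being a limit.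

Compound 3 `CCOC(=O)Nc1cc2c(nc(SCc3ccc(OC)cc3)n2N)c(N)n1` differs from compound 2 by methoxy in place of hydrogen on an aromatic carbon, para to a large group, so that benzyl becomes 4-methoxybenzyl. Going by the values given here, the one measured step concerns the sulfur substituent, not a group on the benzyl ring, so it offers no direct guide here; with no step of the same kind available, the expectation in this assay is no change beyond the scatter, that is no change at the digits printed from compound 2 to compound 3 (within the scatter). Compound 3 is therefore estimated at 600 nM, within a range of 200 nM to 1800 nM.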

Compound 3, half-maximal inhibitory concentration: 60 nM
For compound 3 the middle estimate is 10-fold (1.00 log units) above the measured one; measured number outside the range, below it.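

The ring of the benzyl group is not just a passive end to the sulfur substituent. In this assay, methoxy in place of hydrogen on an aromatic carbon, para to a large group, gives a 10-fold lower number from compound 2 to compound 3 (1.00 log units; beyond the scatter). So far only the presence of the benzyl group had been seen to matter, whereas this shows that what the ring carries counts as well, and the whole change from the free sulfur-bound hydrogen to 4-methoxybenzyl comes to an at least 500-fold lower number from compound 1 to compound 3 (2.69 log units; beyond the scatter), a size known only as a lower bound: the limit of > 30000 nM in this assay, at which 1 of the 3 values shown sits.

A single substituted ring cannot show whether this gain belongs to methoxy itself, which a hydroxyl group, a chlorine atom or an ethoxy group in the same place could help to settle. Going by these compounds, it also remains open whether other places on the ring would respond in the same way, and how a longer chain between the sulfur and the phenyl ring would compare with the benzyl arm.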